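The compounds below may be only part of what the source reports. "The series", "measured", "known", "first", "only" and "open" are said of these compounds alone.

Measured so far:
compound 1, `Cn1ncc2c(=O)n(-c3ccccc3)c(SC(C)(C)c3ccccc3)nc21`: 2200 nM
compound 2, `COc1cccc(C(C)Sc2nc3c(cnn3C)c(=O)n2-c2ccccc2)c1`: 108 nM

In an assay on isolated protein for inhibition of retinal dehydrogenase 2 (Homo sapiens) (a higher number here means a weaker inhibitor, a lower number a stronger inhibitor), compound 2 gives 108 nM, the lowest of the two numbers recorded. The nearest, compound 1, gives 2200 nM, a higher number and a gap well beyond the usual scatter. Compound 3, `CC(Sc1nc2c(cnn2C)c(=O)n1-c1ccccc1)c1cccc(F)c1`, has not yet been measured in this assay. It differs from compound 2 by fluoro in place of methoxy on an aromatic carbon; one bond further out this reads as 3-methoxyphenyl to 3-fluorophenyl. Among the compounds with values here, no pair of measured compounds shows this change, so nothing measured here tells its size. The expected step is small, leaning toward a higher number, and not clearly beyond the scatter: a 1.7-fold higher number from compound 2 to compound 3 (0.22 log units; within the scatter). For compound 3 the estimated value in this assay is 180 nM, with a range from 60 nM to 550 nM.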

Compound 3, half-maximal inhibitory concentration: 110 nM
Compound 3: the middle estimate sits 1.6-fold (0.21 log units) above what was measured; the range from low to high includes it.
By their numbers in this assay, from the lowest: compounds 2 and 3 (each within the scatter of the next); then compound 1.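

In this assay, the position meta to a large group on the aromatic ring takes fluoro in place of methoxy with a 1.0-fold higher number from compound 2 to compound 3 (0.01 log units; within the scatter), so 3-fluorophenyl and 3-methoxyphenyl cannot be told apart here, and the methoxy is not required to reach this level. On the sulfur, 1-(3-fluorophenyl)ethyl in place of 1-methyl-1-phenylethyl gives a 20-fold lower number from compound 1 to compound 3 (1.30 log units; beyond the scatter), a step that covers both the ring substituent and the branching, and these compounds do not separate the two. No measurement available here bears on why the two ring substituents read alike.

Still open, on these data alone, is whether chloro, hydroxy or an amine at this same position would hold the value. Also open, as far as these compounds go, is how the bare phenyl compares, with only a hydrogen at that place.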